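The source may hold more compounds than are shown below. What is called first, only, known or untested is meant among the compounds shown, and "the series" means these compounds.

Compound 1 `CCOC(=O)C1=C(C)NC(C)=C(C(=O)OCC)C1c1ccc(OCC(=O)NCc2ccccc2)cc1`: in a functional assay on the whole organism (strain Wistar) for inhibition, with Rattus norvegicus as the target, read by paw edema, with stated times of 30 min and 1 h, at a dose of 20 mg/kg (on this read-out lower numbers stand for less inhibition and higher numbers for more inhibition at the one dose given (going by the name of the read-out)), compound 1 gives 16.1%.
Compound 2 `CCOC(=O)C1=C(C)NC(C)=C(C(=O)OCC)C1c1ccc(OCC(=O)Nc2c(C)cccc2C)cc1`: compound 2 gives 26.3%.
Compound 3 `CCOC(=O)C1=C(C)NC(C)=C(C(=O)OCC)C1c1ccc(OCC(=O)n2nc(C)cc2C)cc1`: compound 3 gives 32.7%.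

Compound 3 holds the highest of the three numbers. Its lead over compound 2 is within the scatter, since a number 6.4 percentage points higher from compound 2 to compound 3 (within the scatter), whereas its lead over compound 1 is beyond it, since a number 16.6 percentage points higher from compound 1 to compound 3 (beyond the scatter). Compound 4 `CCOC(=O)C1=C(C)NC(C)=C(C(=O)OCC)C1c1ccc(OCC(=O)NN2C(=O)c3ccccc3C2=O)cc1` has not yet been measured. It differs from compound 3 in one place: a group of 12 heavy atoms (8 carbon, 2 nitrogen, 2 oxygen; one five-membered non-aromatic ring with 1 hetero atom, one six-membered aromatic ring of carbon only) in place of a group of 7 heavy atoms (5 carbon, 2 nitrogen; one five-membered aromatic ring with 2 hetero atoms), on a carbonyl carbon.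

For the measured compounds named here, the steps that bear on this change are the two that end at compound 3. In both, a group bearing a hydrogen-bond donor on the carbonyl carbon gave way to the 3,5-dimethyl-1H-pyrazol-1-yl, and the number rose, modestly in a number 16.6 percentage points higher from compound 1 to compound 3 (beyond the scatter) and within the scatter in a number 6.4 percentage points higher from compound 2 to compound 3 (within the scatter). Compound 4 moves the other way, returning a group with one hydrogen-bond donor to that carbonyl carbon. Going by the values given here, no measured step covers this particular group, so the expectation rests on the reversal alone. A downward step is therefore expected, of about a number 8.7 percentage points lower from compound 3 to compound 4 (within the scatter). Compound 4 is estimated at 24%, in a range from 12% to 36%.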

Compound 4, a percentage reported as inhibition, in the whole organism at one dose (the size of the read-out at that dose, not a potency): 42.3%
The estimate for compound 4 lay 18.3 percentage points below the measured number; measured number outside the range, above it.
By their numbers in this assay, from the lowest: compound 1; then compounds 2, 3 and 4 (each within the scatter of the next, the first and the last beyond it).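

In this assay the group of 12 heavy atoms on the carbonyl carbon brings back one hydrogen-bond donor, yet it does not separate from the 3,5-dimethyl-1H-pyrazol-1-yl (a number 9.6 percentage points higher from compound 3 to compound 4 (within the scatter)). A donor on this carbonyl carbon therefore does not by itself go with a lower number, and compound 4 goes against the reading suggested by compound 1, compound 2 and compound 3. On the amide-type nitrogen, the group of 11 heavy atoms does clearly better than both 2,6-dimethylphenyl (a number 16 percentage points higher from compound 2 to compound 4 (beyond the scatter)) and benzyl (a number 26.2 percentage points higher from compound 1 to compound 4 (beyond the scatter)).

The compounds shown leave open how a plain morpholine, a simple amine or a carboxylic acid on this carbonyl carbon would compare, and which part of the entering group carries the gain. Nothing given here explains these steps.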